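The source may report more compounds than this note shows. Statements on the series, on what has been measured and on what is new or still open speak of the compounds shown alone.

Measured so far in an ADME assay on the whole organism (strain Sprague-Dawley) for metabolic stability, with Rattus norvegicus as the target (on this read-out higher numbers stand for a longer-lived compound and lower numbers for a shorter-lived compound), are these compounds:

- Compound 1 `O=C1[C@@H](NS(=O)(=O)/C=C/c2ccc(Cl)s2)CCN1c1ccc(C2CCCN2)cc1F` gives 3.4 h 
- Compound 2 `O=C1[C@@H](NS(=O)(=O)c2ccc3cc(Cl)ccc3c2)CCN1c1ccc(C2CCCN2)cc1F` gives 9 h 
- Compound 3 `O=C1[C@@H](NS(=O)(=O)c2ccc3c(Cl)c[nH]c3c2)CCN1c1ccc(C2CCCN2)cc1F` gives 11 h 

Compound 2 sits within the scatter of compound 3 (a 1.2-fold higher number from compound 2 to compound 3 (0.09 log units; within the scatter)) and clearly apart from compound 1 (a 2.6-fold higher number from compound 1 to compound 2 (0.42 log units; beyond the scatter)). Compound 4 `O=C1[C@@H](NS(=O)(=O)c2ccc3cc(Cl)ccc3c2)CCN1c1ccc([C@@H]2CCCN2)cc1F` has the same atoms and bonds as compound 2 (the two compounds have the same atoms and bonds; at least one stereo element is drawn with a configuration in one of them and without one in the other: 1 of 2 stereo elements differ; a stereocentre at a saturated ring carbon is drawn without a configuration in compound 2 and S in compound 4). The three measured steps all exchange the group on the sulfonyl sulfur. Two of them are modest but beyond the scatter (a 2.6-fold higher number from compound 1 to compound 2 (0.42 log units; beyond the scatter) and a 3.2-fold higher number from compound 1 to compound 3 (0.51 log units; beyond the scatter)), while the third stays within it (a 1.2-fold higher number from compound 2 to compound 3 (0.09 log units; within the scatter)). None of them alters the configuration at the saturated ring carbon, so none measures a change of this kind, and their sizes cannot be carried over to it. With no group exchanged, no step beyond the scatter is expected in this assay, in either direction. The expected change is small (no change at the digits printed from compound 2 to compound 4 (within the scatter)). The half-life estimated for compound 4 is 9 h (expected range 5 h to 16 h).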

Compound 4, half-life: 7.5 h
Compound 4: middle estimate off by 1.2-fold (0.08 log units), on the high side; the measured number falls inside the stated range.
By their numbers in this assay, from the lowest: compound 1; then compounds 4, 2 and 3 (each within the scatter of the next).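

Going by these compounds alone, this is the first step that leaves the group on the sulfonyl sulfur alone and touches only the stereocentre at the saturated ring carbon. In this assay, drawing that carbon as S rather than without a configuration keeps the half-life within the scatter (a 1.2-fold lower number from compound 2 to compound 4 (0.08 log units; within the scatter)), so this comparison gives no sign that the S configuration at this position sets the half-life apart. How far that reading goes is bounded by one fact: the fact that one of compounds 2 and 4 is drawn with a defined configuration and the other without, at the place where they differ

On these data alone, the composition of compound 2 at this carbon is not stated, so the half-life that goes with the R configuration remains unknown. Also open, as far as these compounds go, is how the half-life would respond if a primary amine or a carboxylic acid replaced the saturated ring that carries this stereocentre.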